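A few compounds are considered here, and "the series" means these few. Any claim that something is new, unique, unknown or untested is made for them only; others in the source may bear on it.

Compound 1 `Nc1ccccc1NC(=O)/C=C/c1ccc(CSc2ccc(Cl)cc2)cc1`: 55.3%
Compound 2 `COc1ccc(SCc2ccc(C(=O)Nc3ccccc3N)cc2)cc1`: 45.7%

In a functional assay on A549 cells (Homo sapiens) for inhibition, read by CCK-8 assay, with a stated time of 72 h, tested at 2 uM (on this read-out higher numbers stand for more inhibition of growth at the one concentration tested and lower numbers for less inhibition of growth), compound 1 gives 55.3% and compound 2 gives 45.7%, so the two stand level within the usual scatter. Compound 3 `Nc1ccccc1NC(=O)/C=C/c1ccc(CSc2ccc(F)cc2)cc1` keeps the core of compound 1 and carries one change, fluoro in place of chloro on an aromatic carbon, para to a large group. Going by the values given here, no measured pair shows this swap, so no step beyond the scatter is expected, in either direction, from the 55.3% of compound 1. The expected outcome is an estimated a number 3.3 percentage points lower from compound 1 to compound 3 (within the scatter). For compound 3 the estimated value is 52%, with an expected range of 38% to 66%.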

Compound 3, percent growth inhibition at one concentration: 51.2%
The estimate for compound 3 lay 0.8 percentage points above the measured number; measured number inside the range.
By their numbers in this assay, from the lowest: compounds 2, 3 and 1 (each within the scatter of the next).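

Fluoro in place of chloro on an aromatic carbon, para to a large group, gives a number 4.1 percentage points lower from compound 1 to compound 3 (within the scatter) in this assay and so leaves the 4-chlorophenyl and 4-fluorophenyl compounds level. Going by these compounds alone, this is the first single-place comparison, and at this position it shows that the two halogens cannot be told apart at the one concentration tested. Nothing at hand explains this result.

The compounds shown leave open how an amine or a carboxylic acid in this place would read. They also leave open whether the same swap would read alike on the core of compound 2.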